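This account rests on a few compounds, and the source may have more. Where it says the series, first, only, none or still open, it means among the compounds named here.

Working notes on the series. Compound 1 `C=CCn1c(=O)/c(=C\c2ccccc2Cl)[nH]c(=O)/c1=C\c1ccccc1OC` and compound 2 `C=CCn1c(=O)/c(=C\c2cccc(Br)c2)[nH]c(=O)/c1=C\c1ccccc1OC` share a core with compound 3 `C=CCn1c(=O)/c(=C\c2ccc(F)c(Br)c2)[nH]c(=O)/c1=C\c1ccccc1OC` and differ from one another only in the ring on the double-bonded chain carbon. Among the measured compounds shown here, in a functional assay on MCF7 cells (Homo sapiens) for cytotoxicity, read by CCK-8 assay, with a stated time of 72 h (a higher number here means a weaker inhibitor, a lower number a stronger inhibitor), compound 1 gives 4700 nM, and compound 2 gives 5400 nM; the step of a 1.1-fold higher number from compound 1 to compound 2 (0.06 log units; within the scatter) is the only paired comparison so far. Compound 3 stands apart: in this assay compound 3 gives "not active" (no number reported), so no number is available for it and its position relative to compound 1 and compound 2 cannot be stated.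

Compound 4 `C=CCn1c(=O)/c(=C\c2ccccc2F)[nH]c(=O)/c1=C\c1ccccc1OC` is the next one to test. The change is 2-fluorophenyl in place of 3-bromo-4-fluorophenyl on a double-bonded chain carbon bound to an aromatic carbon. For the measured compounds named here, no measured step bears directly on it, since compound 3 has no number; the only guide is that compound 1 and compound 2, carrying 2-chlorophenyl and 3-bromophenyl at the same place, both give numbers in the same range. On that basis compound 4 is expected to fall near those two rather than to share the outcome of compound 3, with an estimated value of 6000 nM and a range from 2500 nM to 25000 nM in this assay.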

Compound 4, half-maximal inhibitory concentration: 23000 nM
For compound 4 the middle estimate is 3.8-fold (0.58 log units) below the measured one; measured number inside the range.
By their numbers in this assay, from the lowest: compounds 1 and 2 (each within the scatter of the next); then compound 4.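

In this assay, among the compounds shown here, this place on a double-bonded chain carbon bound to an aromatic carbon now shows a clear dependence on the ring: fluoro in place of chloro on an aromatic carbon gives a 4.9-fold higher number from compound 1 to compound 4 (0.69 log units; beyond the scatter) and 2-fluorophenyl in place of 3-bromophenyl gives a 4.3-fold higher number from compound 2 to compound 4 (0.63 log units; beyond the scatter) while the only earlier step, a 1.1-fold higher number from compound 1 to compound 2 (0.06 log units; within the scatter), showed no such separation. The change in halogen at this place therefore matters among compounds 1, 2 and 4, though any step involving compound 3 cannot be read, as compound 3 has no number. Nothing at hand accounts for the size of these steps.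

Open, going by these compounds, is whether a ring carrying an amine or a carboxylic acid at this place would keep a number in this assay. Also open, on these data alone, is whether these steps would persist with a longer chain elsewhere on the shared core.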